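Swapping the Distal Aryl Group for Isopropyl

The source may hold more compounds than are shown below. What is called first, only, known or untested is meant among the compounds shown, and "the series" means these compounds.

Compound 1 `COc1ccc(F)cc1CNCCCNc1ccnc2cc(Cc3ccc(C#N)cc3)ccc12` gives 9.47 in a physicochemical assay for acid dissociation. It stands level with compound 3 `COc1cccc(CNCCCNc2ccnc3cc(Cc4ccc(C#N)cc4)ccc23)c1O`, which gives 9.47, the two together being the highest of three numbers, while compound 2 `COc1cccc(CNCCCNc2ccnc3cc(Oc4cccc(N(C)C)c4)ccc23)c1O` gives 9.28. Compound 4 `COc1ccc(F)cc1CNCCCNc1ccnc2cc(CC(C)C)ccc12` differs from compound 1 by isopropyl in place of 4-cyanophenyl on a saturated chain carbon bound to an aromatic carbon. Going by the values given here, two measured steps bear on it: a number 0.19 log units higher from compound 2 to compound 3 (within the scatter), which alters the same region, and no change at the digits printed from compound 1 to compound 3 (within the scatter), which alters the other end of the molecule. Both were within the scatter, so no step beyond the scatter is expected here either, in either direction: the expected step is a number 0.02 log units lower from compound 1 to compound 4 (within the scatter). Compound 4 is therefore estimated at 9.45, between 9.15 and 9.75.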

Compound 4, acid dissociation constant: 9.47
For compound 4 the middle estimate is 0.02 log units below the measured one; low and high end bracket the measured number.
By their numbers in this assay, from the lowest: compounds 2, 1, 3 and 4 (each within the scatter of the next).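

In this assay, isopropyl in place of 4-cyanophenyl gives no change at the digits printed from compound 1 to compound 4 (within the scatter). The earlier step at this place compared two groups that both carry an aromatic ring, whereas isobutyl has no ring and no nitrile. Removing both features, and much of the group's size, therefore still leaves this number within the scatter.

From the compounds shown here alone, whether a carboxylic acid or an amine at this place would also leave the number within the scatter remains open. Nothing available explains why the number holds steady here.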